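This account rests on a few compounds, and the source may have more. Where it says the series, first, only, none or still open, it means among the compounds named here.

Compound 1 `O=C(CCC(=O)OCCCCCCSc1ccc([N+](=O)[O-])c2nonc12)Nc1ccc(Br)cc1` and compound 2 `CN(C)CCCNC(=O)CCC(=O)OCCCCCCSc1ccc([N+](=O)[O-])c2nonc12` share the same core and differ only in the group on the amide-type nitrogen. In an assay on isolated protein for inhibition of glutathione S-transferase Mu 2 (Homo sapiens), with a stated time of 10 min (a higher number here means a weaker inhibitor, a lower number a stronger inhibitor), compound 1 gives 32000 nM, while compound 2 gives 90 nM. For the measured compounds named here, the single measured step, a 360-fold lower number from compound 1 to compound 2 (2.55 log units; beyond the scatter), leaves compound 2 with the lowest of the two numbers, compound 1 being the nearest at a far higher one. Compound 3 `CCN(CC)CCCNC(=O)CCC(=O)OCCCCCCSc1ccc([N+](=O)[O-])c2nonc12` is not yet measured. It differs from compound 2 by diethylamino in place of dimethylamino on a saturated chain carbon, three bonds along the chain from an amide-type nitrogen. Going by the values given here, no measured step touches this change directly: the only step at hand, a 360-fold lower number from compound 1 to compound 2 (2.55 log units; beyond the scatter), exchanged the whole group on the amide-type nitrogen, whereas here the dimethylamino end of the same chain is merely widened to diethylamino. That step bears on the question only in showing that this group governs the number in this assay; nothing in it says whether a larger alkylamine moves the number up or down. On that footing compound 3 is expected to remain close to compound 2, with a step of a 1.1-fold higher number from compound 2 to compound 3 (0.05 log units; within the scatter) that is not expected to exceed the scatter. The estimate for compound 3 in this assay is 100 nM, between 35 nM and 300 nM.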

Compound 3, half-maximal inhibitory concentration: 440 nM
Compound 3: the middle estimate sits 4.4-fold (0.64 log units) below what was measured; measured number above the stated range.
By their numbers in this assay, from the lowest: compound 2; then compound 3; then compound 1.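

For the compounds shown here, the earlier compounds showed only that exchanging the whole group on the amide-type nitrogen moves the number, whereas this result shows that the alkyl groups on the amine nitrogen also count: in this assay, diethylamino in place of dimethylamino on a saturated chain carbon, three bonds along the chain from an amide-type nitrogen, gives a 4.9-fold higher number from compound 2 to compound 3 (0.69 log units; beyond the scatter) and so lies beyond the scatter. The change costs only part of the earlier gain, since the 3-(diethylamino)propyl group in place of 4-bromophenyl on the amide-type nitrogen still gives a 73-fold lower number from compound 1 to compound 3 (1.86 log units; beyond the scatter) in the same assay. No measurement is available that would explain why diethylamino and dimethylamino differ here.

On these data alone, with only these two alkylamines compared, it remains open whether the number would keep rising with a dipropylamino group, or how it would respond to a ring amine such as pyrrolidine or morpholine. Also open, as far as these compounds go, is whether a primary amine or a methylamino group would give a lower number than dimethylamino, and how a longer or shorter chain carrying the dimethylamino group would compare.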